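Chloro to nitro swap carried from one core to another

This account rests on a few compounds, and the source may have more. Where it says the series, first, only, none or still open, it means among the compounds named here.

Compound 1 `CN(C)C(=O)N(Cc1ccco1)Cc1cc(Cl)ccc1O` and compound 2 `CCOC(=O)N1CCC(N(Cc2cc(Cl)ccc2O)C(=O)N(C)C)CC1` share a core; the difference between the two cores is not broken down here. In a functional assay on K562 cells (Homo sapiens) for antiproliferative activity, read by MTT assay, with a stated time of 48 h (a lower number here means a stronger inhibitor, a higher number a weaker inhibitor), compound 1 gives 28600 nM and compound 2 gives 38400 nM, two numbers within the usual scatter of each other. Compound 3 `CN(C)C(=O)N(Cc1ccco1)Cc1cc([N+](=O)[O-])ccc1O` carries on the core of compound 1 the change (nitro in place of chloro on an aromatic carbon). In this assay compound 3 gives 28600 nM, so that no change at the digits printed from compound 1 to compound 3 (within the scatter). Compound 4 `CCOC(=O)N1CCC(N(Cc2cc([N+](=O)[O-])ccc2O)C(=O)N(C)C)CC1` carries the same change on the core of compound 2, (nitro in place of chloro on an aromatic carbon). For the measured compounds named here, the only measured instance of this change left the number where it was, so the step is expected to be about as small here, a 1.0-fold lower number from compound 2 to compound 4 (0.00 log units; within the scatter), because no change at the digits printed from compound 1 to compound 3 (within the scatter). Compound 4 is therefore estimated at 38000 nM, between 19000 nM and 76000 nM.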

Compound 4, half-maximal inhibitory concentration: 38400 nM
For compound 4 the middle estimate is 1.0-fold (0.00 log units) below the measured one; measured number inside the range.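

In this assay, nitro in place of chloro on the second core gives no change at the digits printed from compound 2 to compound 4 (within the scatter). Set beside the first core, the swap reads alike on both: the same change on two cores in this assay, no change at the digits printed (within the scatter) from compound 1 to compound 3 and no change at the digits printed (within the scatter) from compound 2 to compound 4, 1.0-fold (0.00 log units) apart, within the scatter of two such steps This shows only that the swap carries over between these two cores in this one assay; it does not show that chloro and nitro are interchangeable elsewhere, and a swap that moves no number on either core cannot show whether a real step would carry over.

Still open, going by these compounds, is whether any other group at this place, para to a hydroxy group, such as an amine or a carboxylic acid, would shift the number on either core. The compounds shown also leave open what replacing the hydroxy group itself would do.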